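The compounds below may be only part of what the source reports. "The series", "measured", "known", "first", "only" and "open" are said of these compounds alone.

Among the measured compounds shown here, in an ADME assay on MT4 cells (Homo sapiens) for cytotoxicity (on this read-out higher numbers stand for lower toxicity in this test and lower numbers for higher toxicity in this test), compound 2 `Fc1cccc(NC(=S)Nc2cccc(C(F)(F)F)c2)c1` gives 20000 nM, the only true number so far. Compound 1 `CC(=O)NC(=S)Nc1cccc(C(F)(F)F)c1` reads > 100000 nM, a limit of the assay and not a number. Compound 3 `FC(F)(F)c1cccc(NC(=S)NCc2ccco2)c1` differs from compound 2 by (furan-2-yl)methyl in place of 3-fluorophenyl on an amide-type nitrogen, with (furan-2-yl)methyl in place of 3-fluorophenyl on an amide-type nitrogen. For the measured compounds named here, the one measured step bearing on this, an at least 5.0-fold lower number from compound 1 to compound 2 (0.69 log units; beyond the scatter), brought in 3-fluorophenyl on such a nitrogen, so removing that group is expected to give a modest move to a higher number. The estimated change is a 2.0-fold higher number from compound 2 to compound 3 (0.30 log units; within the scatter). Compound 3 is expected near 40000 nM, within 15000 nM to 100000 nM.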

Compound 3, half-maximal cytotoxic concentration: 43000 nM
The estimate for compound 3 lay 1.1-fold (0.03 log units) below the measured number; the measured number falls inside the stated range.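

On the amide-type nitrogen, (furan-2-yl)methyl in place of 3-fluorophenyl gives a 2.2-fold higher number from compound 2 to compound 3 (0.33 log units; beyond the scatter) in this assay, so two ring-bearing groups at this position now differ beyond the scatter. The read-out here therefore depends on more than the presence of a ring. (Furan-2-yl)methyl in place of acetyl gives an at least 2.3-fold lower number from compound 1 to compound 3 (0.36 log units; beyond the scatter), a step whose full size stays unknown: the limit of > 100000 nM in this assay, at which 1 of the 3 values shown sits.

Still open, from the compounds shown here alone, is how an amine, a carboxylic acid or a longer alkyl chain on this nitrogen would read. Also open, going by these compounds, is whether the step follows the furan ring or the methyl link.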